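Dimethylamino in Place of Methyl: Expected Paw Edema Inhibition

The compounds below may be only part of what the source reports. "The series", "measured", "known", "first", "only" and "open" are said of these compounds alone.

Compound 1 `Cc1ccc(/C=C2\S/C(=N/c3nccs3)NC2=O)cc1`: 47%
Compound 2 `O=C1N/C(=N\c2nccs2)S/C1=C\c1cccc(Br)c1`: 42.7%

In a functional assay on the whole organism (strain AKR) for inhibition, with Mus musculus as the target, read by paw edema, with a stated time of 3.5 h, at a dose of 0.01 mmol/kg by the intraperitoneal route (a lower number here means less inhibition, a higher number more inhibition at the dose given (going by the name of the read-out)), compound 1 gives 47%. Compound 2 gives 42.7%, a number within the usual scatter of that of compound 1, so the two cannot be set apart. Compound 3 `CN(C)c1ccc(/C=C2\S/C(=N/c3nccs3)NC2=O)cc1` differs from compound 1 by dimethylamino in place of methyl on an aromatic carbon. Within the data shown here, no step between measured compounds is known, so nothing on record tells how large this change might read. The expected step from compound 1 to compound 3 is a number 2 percentage points lower from compound 1 to compound 3 (within the scatter), none beyond the scatter. Compound 3 is estimated at 45%, with a range from 28% to 62%.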

Compound 3, a percentage reported as inhibition, in the whole organism at one dose (the size of the read-out at that dose, not a potency): 67.3%
Estimate against measurement, compound 3: 22.3 percentage points below; measured number above the stated range.
By their numbers in this assay, from the lowest: compounds 2 and 1 (each within the scatter of the next); then compound 3.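

In this assay, dimethylamino in place of methyl on an aromatic carbon, para to a large group, gives a number 20.3 percentage points higher from compound 1 to compound 3 (beyond the scatter). Among these compounds, this is the first step on record, and it shows that the read-out at this dose responds to the group at this position. Nothing at hand says why the number moves.

A single step cannot tell whether the nitrogen or the larger group carries the change. The compounds shown leave open how a primary amine, a methoxy group or the longer diethylamino would read at this position.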